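Swapping a nitro group for iodine on a thiosemicarbazone

The source may report more compounds than this note shows. Statements on the series, on what has been measured and on what is new or still open speak of the compounds shown alone.

Of the compounds shown here, two sharing one core have been tested in a functional assay on T98G cells (Homo sapiens) for cytotoxicity, read by MTT assay, with a stated time of 48 h; a higher number here means a weaker inhibitor, a lower number a stronger inhibitor. Compound 1 `C/C(=N\NC(=S)Nc1ccccc1I)c1ccccn1` gives 8.09 nM in this assay. Compound 2 `CC(=NNC(=S)Nc1cccc([N+](=O)[O-])c1)c1ccccn1` gives 140 nM in this assay, the higher of the two numbers and therefore the weaker inhibitor; its gap to compound 1 lies beyond the usual scatter. The next compound, compound 3 `CC(=NNC(=S)Nc1cccc(I)c1)c1ccccn1`, is compound 2 with one change: iodo in place of nitro on an aromatic carbon. Going by the values given here, no measured pair shows exactly this swap, so the size of the step is open. Since compound 1, which also carries an iodo group, gives 8.09 nM, an iodo-bearing compound on this core can reach a low number, and compound 3 is expected to sit below compound 2 by a step of a 5.6-fold lower number from compound 2 to compound 3 (0.75 log units; beyond the scatter). For compound 3 the estimated value is 25 nM, with a plausible range from 6 nM to 100 nM.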

Compound 3, half-maximal inhibitory concentration: 61 nM
For compound 3 the middle estimate is 2.4-fold (0.39 log units) below the measured one; low and high end bracket the measured number.
By their numbers in this assay, from the lowest: compound 1; then compound 3; then compound 2.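

The swap now has a direct reading: iodo in place of nitro, on an aromatic carbon meta to a large group, gives a 2.3-fold lower number from compound 2 to compound 3 (0.36 log units; beyond the scatter) in this assay, a modest step that still lies beyond the scatter. The iodo group therefore goes with a lower number at this position, but carrying one does not by itself reach the level of compound 1. Compound 3 gives 61 nM, while compound 1, with its iodo group elsewhere on the same ring, gives 8.09 nM.

No available evidence explains why this swap lowers the number. Also open, on these data alone, is whether an amine or a carboxylic acid on this same carbon would give a lower or higher number than iodo.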